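A Small Added Methyl on a Sulfur Chain

The source may hold more compounds than are shown below. What is called first, only, known or untested is meant among the compounds shown, and "the series" means these compounds.

Measured in an ADME assay on MT4 cells (Homo sapiens) for activation, read by MTT assay; on this read-out higher numbers stand for lower toxicity in this test and lower numbers for higher toxicity in this test:
- compound 1 `CCc1c(C(C)c2c(F)cccc2Cl)nc(SC(C)CC)[nH]c1=O`: > 3000 nM
- compound 2 `CCCSc1nc(C(C)c2c(F)cccc2F)c(CC)c(=O)[nH]1`: > 3000 nM

Both values are limits of the assay and not numbers, and they give the same picture: the limit of > 3000 nM in this assay, at which 2 of the 2 values shown sit. Compound 2 stands only at its limit of > 3000 nM. Compound 3 `CCc1c(C(C)c2c(F)cccc2F)nc(SC(C)CC)[nH]c1=O` differs from compound 2 by methyl in place of hydrogen on a saturated chain carbon bound to a saturated chain carbon and a sulfur, turning propylsulfanyl into (sec-butyl)sulfanyl. Among the measured compounds shown here, no measured step shows what this change does, so the expectation rests only on the limit of compound 2 at > 3000 nM. The expected step that the limit leaves unreadable from compound 2 to compound 3 is small, with no change beyond the scatter in either direction. Compound 3 is estimated at 5000 nM, with an expected range of 2000 nM to 30000 nM.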

Compound 3, half-maximal cytotoxic concentration: > 3000 nM
Compound 3: no number, only a limit (the forecaster's own chance of this, stated with the estimate: 75%); the middle value is on the limit's open side.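

Compound 3, like compound 1 and compound 2, gives only a limit and not a number, so no step between them can be read: the limit of > 3000 nM in this assay, at which 3 of the 3 values shown sit.

As far as these compounds go, whether the added methyl or fluoro in place of chloro changes toxicity at all remains open.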